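Swapping 4-methylpiperazin-1-yl for a silicon-bearing group

The source may report more compounds than this note shows. Statements on the series, on what has been measured and on what is new or still open speak of the compounds shown alone.

Compound 1 `CC(C)=CCC[C@]1(C)/C=C/[C@@H](OC(=O)C=C(C)C)[C@](C)(O)/C=C/C(=O)/C(CN(C)C)=C\C1`: 140 nM
Compound 2 `CC(C)=CCC[C@]1(C)/C=C/[C@@H](OC(=O)C=C(C)C)[C@](C)(O)/C=C/C(=O)/C(CN2CCN(C)CC2)=C\C1`: 840 nM

In a functional assay on HL-60 cells (Homo sapiens) for antiproliferative activity, read by MTT assay, with a stated time of 48 h (a higher number here means a weaker inhibitor, a lower number a stronger inhibitor), compound 2 has the higher of the two numbers and is therefore the weaker inhibitor of the pair. Compound 3 `CC[Si](CC)(CC)C/C1=C/C[C@](C)(CCC=C(C)C)/C=C/[C@@H](OC(=O)C=C(C)C)[C@](C)(O)/C=C/C1=O`, not yet measured, differs from compound 2 as follows: a group of 7 heavy atoms (6 carbon, 1 silicon; no ring) in place of a group of 7 heavy atoms (5 carbon, 2 nitrogen; one six-membered non-aromatic ring with 2 hetero atoms), on a saturated chain carbon bound to a double-bonded ring carbon. Among the compounds with values here, one measured step bears on this place: a 6.0-fold higher number from compound 1 to compound 2 (0.78 log units; beyond the scatter). That step is modest but beyond the scatter. It relates two nitrogen-bearing groups, whereas the entering group holds no nitrogen, so it gives a rough size but no reliable direction. No clear shift beyond the scatter is therefore expected in this assay, although a modest step either way remains possible. The expected change is a 1.4-fold lower number from compound 2 to compound 3 (0.15 log units; within the scatter). For compound 3 the estimated value is 600 nM, with an expected range of 150 nM to 2500 nM.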

Compound 3, half-maximal inhibitory concentration: 2810 nM
Beside the measured number, compound 3's estimate is 4.7-fold (0.67 log units) below it; measured number above the stated range.
By their numbers in this assay, from the lowest: compound 1; then compound 2; then compound 3.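

In this assay, the silicon-bearing group, which holds no nitrogen, gives a 3.3-fold higher number from compound 2 to compound 3 (0.52 log units; beyond the scatter) at this saturated chain carbon bound to a double-bonded ring carbon, so the change is a clear loss rather than a neutral swap. Set against dimethylamino, the same group gives a 20-fold higher number from compound 1 to compound 3 (1.30 log units; beyond the scatter) and is the largest step in the set; both nitrogen-bearing groups therefore have lower numbers than the group without nitrogen, with no compound shown going against this. No measurement is available that explains this order.

On these data alone, it remains open whether the rise goes with the loss of nitrogen or with the silicon itself, a question that an all-carbon group such as neopentyl at this place would separate. A morpholin-4-yl group would show how the ring amine series extends beyond 4-methylpiperazin-1-yl.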